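Urea Side Chain Swap on a Shared Quinazoline-Type Core

This account rests on a few compounds, and the source may have more. Where it says the series, first, only, none or still open, it means among the compounds named here.

Measured compounds:
- Compound 1, `CN1CCN(Cc2ccc(NC(=O)Nc3ccc4ncnc(Nc5cccc(C(F)(F)F)c5)c4c3)cc2)CC1`: 2410 nM in a functional assay on A-431 cells (Homo sapiens) for antiproliferative activity, read by MTT assay, with a stated time of 72 h; on this read-out lower numbers stand for stronger inhibition and higher numbers for weaker inhibition
- Compound 2, `O=C(Nc1cccc(CN2CCCC2)c1)Nc1ccc2ncnc(Nc3cccc(C(F)(F)F)c3)c2c1`: 1230 nM in this assay

Compound 1 and compound 2 share the same core and differ only in the group attached to the urea nitrogen. In this assay compound 2 gives 1230 nM, and compound 1 gives 2410 nM; the gap between these two numbers lies within the usual scatter of repeated measurements, so the two compounds cannot be told apart on this read-out.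

Compound 3, `COc1ccc(NC(=O)Nc2ccc3ncnc(Nc4cccc(C(F)(F)F)c4)c3c2)cc1`, has not yet been measured. It differs from compound 2 in one place: 4-methoxyphenyl in place of 3-((pyrrolidin-1-yl)methyl)phenyl on an amide-type nitrogen. The group that leaves carries a nitrogen in a five-membered non-aromatic ring, while the group that enters carries an oxygen on the aromatic ring. Within the data shown here, no step between measured compounds tells how such a change plays out here, so the expectation rests only on compound 2 and the size of the change.

The step from compound 2 to compound 3 in this assay is expected to be small, a 1.2-fold higher number from compound 2 to compound 3 (0.09 log units; within the scatter), and not clearly beyond the scatter in either direction. Compound 3 is therefore estimated at 1500 nM, with a range from 400 nM to 6000 nM.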

Compound 3, half-maximal inhibitory concentration: 4950 nM
For compound 3 the middle estimate is 3.3-fold (0.52 log units) below the measured one; the range from low to high includes it.
By their numbers in this assay, from the lowest: compounds 2 and 1 (each within the scatter of the next); then compound 3.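

On the amide-type nitrogen, this assay now shows a change that clears the scatter: 4-methoxyphenyl in place of 3-((pyrrolidin-1-yl)methyl)phenyl gives a 4.0-fold higher number from compound 2 to compound 3 (0.60 log units; beyond the scatter) for this swap. Methoxy in place of (4-methylpiperazin-1-yl)methyl on an aromatic carbon points the same way, with a 2.1-fold higher number from compound 1 to compound 3 (0.31 log units; beyond the scatter) as a modest step, so among these three compounds, both side groups carrying a saturated nitrogen ring give lower numbers than 4-methoxyphenyl. No measurement at hand explains these shifts.

The step from compound 2 to compound 3 changes both the group and its numbered place on the phenyl ring, so the two changes remain tangled. On these data alone, how a plain phenyl, a 3-methoxyphenyl or a phenyl bearing a carboxylic acid would behave here remains open.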